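Chloro in place of cyano on compound 3

This account rests on a few compounds, and the source may have more. Where it says the series, first, only, none or still open, it means among the compounds named here.

In a functional assay on DU-145 cells (Homo sapiens) for inhibition, read by MTT assay, with a stated time of 48 h (a higher number here means a weaker inhibitor, a lower number a stronger inhibitor), compound 1 `CCc1ccc(-c2nc3ccccn3c2Sc2ccccc2)cc1` gives 84500 nM, compound 2 `C(=C/c1nc2ccccn2c1Sc1ccccc1)\c1ccccc1` gives 22000 nM and compound 3 `N#Cc1ccc(-c2nc3ccccn3c2Sc2ccccc2)cc1` gives 76500 nM. Compound 3 thus sits in the upper part of these numbers, a 3.5-fold higher number from compound 2 to compound 3 (0.54 log units; beyond the scatter). Compound 4 `Clc1ccc(-c2nc3ccccn3c2Sc2ccccc2)cc1` carries chloro in place of cyano on an aromatic carbon, (chloro in place of cyano on an aromatic carbon). The closest measured exchange, cyano in place of ethyl on an aromatic carbon, stayed within the scatter, a 1.1-fold lower number from compound 1 to compound 3 (0.04 log units; within the scatter). The larger 3.8-fold lower number from compound 1 to compound 2 (0.58 log units; beyond the scatter) came with 2-phenylethenyl in place of 4-ethylphenyl, a different kind of change. No step beyond the scatter is therefore expected in this assay, and the expected step is a 1.1-fold lower number from compound 3 to compound 4 (0.05 log units; within the scatter). Compound 4 is estimated at 68000 nM, with an expected range of 30000 nM to 130000 nM.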

Compound 4, half-maximal inhibitory concentration: 30700 nM
The estimate for compound 4 lay 2.2-fold (0.35 log units) above the measured number, within the range that was stated.
By their numbers in this assay, from the lowest: compounds 2 and 4 (each within the scatter of the next); then compounds 3 and 1 (each within the scatter of the next).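

At this aromatic carbon, the group now makes a difference in this assay: cyano and ethyl had stayed within the scatter of each other, whereas chloro gives a 2.5-fold lower number from compound 3 to compound 4 (0.40 log units; beyond the scatter) and a 2.8-fold lower number from compound 1 to compound 4 (0.44 log units; beyond the scatter). A single chlorine here also brings the 4-chlorophenyl compound level with the 2-phenylethenyl compound, with a 1.4-fold higher number from compound 2 to compound 4 (0.14 log units; within the scatter) lying within the scatter. Nothing measured here accounts for the effect of chloro. From the compounds shown here alone, it remains open how an amine, a carboxylic acid, a methoxy group or a longer chain would behave at this carbon, and whether bromo or fluoro would track with chloro.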